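The source may hold more compounds than are shown below. What is called first, only, known or untested is meant among the compounds shown, and "the series" means these compounds.

Three compounds built on a sugar-derived framework were tested in a functional assay on MCF7 cells (Homo sapiens) for cytotoxicity, in the presence of a further agent that is not named here; on this read-out lower numbers stand for an effect already at smaller amounts and higher numbers for an effect only at larger amounts of compound. Compound 1 `CCCCCCCO[C@@H]1[C@@H](O)[C@@H](OCc2ccccc2)O[C@@H]2CO[C@@H](c3ccc(OC)cc3)O[C@@H]12` carries a free hydroxy group and in this assay gives 2.5 ug/mL. Compound 2 `CCCCCCCO[C@@H]1[C@@H](OCc2ccccc2)[C@@H](OCc2ccccc2)O[C@@H]2CO[C@@H](c3ccc(OC)cc3)O[C@@H]12` is its close relative in which that oxygen carries a benzyl group. For compound 2 this assay reports only a limit, > 20 ug/mL. The structural difference between the two is hydrogen in place of benzyl on an oxygen on a saturated carbon, and the measured step is an at least 8.0-fold lower number from compound 2 to compound 1 (0.90 log units; beyond the scatter). Its true size is not known, as the value of compound 2 is a limit; this is the limit at which two of the three values sit, (the limit of > 20 ug/mL in this assay, at which 2 of the 3 values shown sit).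

Compound 3 `CCCCCCCO[C@@H]1[C@@H](OCc2ccccc2)[C@@H](OCc2ccccc2)O[C@H](CC(C)C)[C@H]1OCc1ccc(OC)cc1` rests on a different core; the difference between the two cores is not broken down here. For compound 3 this assay likewise reports only a limit, > 20 ug/mL.

Compound 4 `CCCCCCCO[C@@H]1[C@@H](O)[C@@H](OCc2ccccc2)O[C@H](CC(C)C)[C@H]1OCc1ccc(OC)cc1` has not yet been measured. It stands to compound 3 as compound 1 stands to compound 2: the change is hydrogen in place of benzyl on an oxygen on a saturated carbon, the same change made at a place described in the same words, and it occurs in two pairs among these compounds. Resting on the earlier step of an at least 8.0-fold lower number from compound 2 to compound 1 (0.90 log units; beyond the scatter), the step to compound 4 is expected to be an at least 5.0-fold lower number from compound 3 to compound 4 (0.69 log units; beyond the scatter). The starting point of this step is a limit rather than a number, and the expectation is correspondingly uncertain. Compound 4 is therefore estimated at 4 ug/mL, most plausibly between 1.5 ug/mL and 25 ug/mL.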

Compound 4, half-maximal effective concentration: 4 ug/mL
Estimate against measurement, compound 4: no gap at the digits printed; measured number inside the range.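

Swapping the benzyl group for hydrogen on the oxygen, a change from benzyloxy to hydroxy, gives in this assay an at least 5.0-fold lower number from compound 3 to compound 4 (0.69 log units; beyond the scatter), so the change that marks the pair of compound 2 and compound 1 is also accompanied by a lower number on the second core. Compound 3 gives > 20 ug/mL, which is a limit and not a number, and compound 2 sits at the same limit: the limit of > 20 ug/mL in this assay, at which 2 of the 4 values shown sit. What carries over is therefore the direction of the step, while its true size on either core stays unknown, and a similar size on both cores cannot be claimed: the same change on two cores in this assay, an at least 8.0-fold lower number (0.90 log units; beyond the scatter) from compound 2 to compound 1 and an at least 5.0-fold lower number (0.69 log units; beyond the scatter) from compound 3 to compound 4; the limit leaves it open whether they differ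

The compounds shown compare only benzyl with hydrogen at this oxygen, leaving open where a methyl ether, an acetyl ester or an amine in place of the hydroxy group would fall on this read-out. They also leave open whether the same step would appear on a core with a longer chain in place of the seven-carbon ether chain these compounds share.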